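The source may hold more compounds than are shown below. What is called first, only, known or untested is meant among the compounds shown, and "the series" means these compounds.

Two measured compounds set the scene. Compound 1 `C#CCn1cnc2c1c(=O)n(C)c(=O)n2C` gives 12000 nM in an assay on cell membranes with adenosine receptor A1 (Rattus norvegicus) as the target (on this read-out higher numbers stand for weaker inhibition and lower numbers for stronger inhibition), and compound 2 `CCCn1c(=O)c2c(ncn2CCC)n(CCC)c1=O` gives 2600 nM in this assay, the lower of the two numbers and beyond the scatter from compound 1. Compound 3 `CCCn1c(=O)c2c(ncn2Cc2ccccc2)n(CCC)c1=O` has not yet been measured. It differs from compound 2 in one place: phenyl in place of ethyl on a saturated chain carbon bound to an aromatic nitrogen, so the propyl on that aromatic nitrogen becomes a benzyl. Going by the values given here, no measured pair shows this kind of change, so the step of a 1.2-fold higher number from compound 2 to compound 3 (0.06 log units; within the scatter) is expected to stay small, within the scatter. Compound 3 is therefore estimated at 3000 nM, likely between 800 nM and 12000 nM.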

Compound 3, inhibition constant: 1000 nM
Compound 3: middle estimate off by 3.0-fold (0.48 log units), on the high side; measured number inside the range.
By their numbers in this assay, from the lowest: compound 3; then compound 2; then compound 1.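

In this assay, replacing propyl with benzyl on this aromatic nitrogen gives a 2.6-fold lower number from compound 2 to compound 3 (0.41 log units; beyond the scatter) and so shows that this position accepts an added six-membered aromatic ring with a modest gain rather than a loss. Going by these compounds alone, this is the first single-place comparison available, and it shows that the group here can move the number beyond the scatter. No evidence on hand explains the gain. On these data alone, it remains open whether the aromatic ring matters or whether a longer chain such as butyl would do the same. As far as these compounds go, how a benzyl carrying an amine or a carboxylic acid would read also remains open.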